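Halogen swap on the aromatic ring, paw edema dose

A few compounds are considered here, and "the series" means these few. Any claim that something is new, unique, unknown or untested is made for them only; others in the source may bear on it.

Measured compounds:
compound 1 `O=C(O)CO/N=C/c1ccc(Cl)cc1` 45 mg/kg
compound 2 `O=C(O)CO/N=C/c1ccc(Br)cc1` 46 mg/kg
compound 3 `COC(=O)CO/N=C(\C)c1ccc(Cl)cc1` 24 mg/kg

In a functional assay on the whole organism for inhibition, with Rattus norvegicus as the target, read by paw edema, with stated times of 1 h and 3 h (a lower number here means that less compound is needed, a higher number that more compound is needed for the effect), compound 1 gives 45 mg/kg and compound 2 gives 46 mg/kg; the change between them, (bromo in place of chloro on an aromatic carbon), made a step of a 1.0-fold higher number from compound 1 to compound 2 (0.01 log units; within the scatter). Compound 3 gives 24 mg/kg in this assay; the difference between the core of compound 1 and the core of compound 3 is not broken down here. Compound 4 `COC(=O)CO/N=C(\C)c1ccc(Br)cc1` is not yet measured. It differs from compound 3 by bromo in place of chloro on an aromatic carbon, the same kind of change as from compound 1 to compound 2, though the group here is para to a group of 9 heavy atoms rather than 7. Because the earlier step was a 1.0-fold higher number from compound 1 to compound 2 (0.01 log units; within the scatter), the step from compound 3 to compound 4 is expected to be about a 1.0-fold higher number from compound 3 to compound 4 (0.02 log units; within the scatter) in this assay. Compound 4 is therefore estimated at 25 mg/kg, between 12 mg/kg and 50 mg/kg.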

Compound 4, dose for half-maximal effect: 14 mg/kg
Compound 4: the middle estimate sits 1.8-fold (0.25 log units) above what was measured; the range from low to high includes it.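

In this assay, bromo in place of chloro on an aromatic carbon gave a 1.7-fold lower number from compound 3 to compound 4 (0.23 log units; within the scatter). Set beside the earlier step, this gives no sign of a difference between the two cores: the same change on two cores in this assay, a 1.0-fold higher number (0.01 log units; within the scatter) from compound 1 to compound 2 and a 1.7-fold lower number (0.23 log units; within the scatter) from compound 3 to compound 4, 1.8-fold (0.24 log units) apart, within the scatter of two such steps. The change thus carries from the core of compound 1 to the core of compound 3 without a resolvable difference, but two pairs, both within the scatter, do not show that the steps are identical or that they would hold on further cores.

The compounds shown leave open how fluoro, methoxy or an amine on that aromatic carbon would read in this assay. They also leave open how the halogen swap would read on a core carrying an amide in place of the ester.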